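The compounds below may be only part of what the source reports. "The series", "measured", "known", "first", "only" and "open" are said of these compounds alone.

Measured compounds, all in a functional assay on OVCAR-3 cells (Homo sapiens) for inhibition, read by sulforhodamine B assay, with a stated time of 48 h; a lower number here means a stronger inhibitor of growth, a higher number a weaker inhibitor of growth:
compound 1, `O=C(Nc1cccc(-n2cc(-c3ccncc3)c(-c3ccc(Cl)c(O)c3)n2)c1)Nc1cccc(C(F)(F)F)c1`, gives 1060 nM
compound 2, `COc1cc(-c2nn(-c3cccc(NC(=O)Nc4cc(C(F)(F)F)cc(C(F)(F)F)c4)c3)cc2-c2ccncc2)ccc1Cl`, gives 411 nM
compound 3, `COc1cc(-c2nn(-c3cccc(NC(=O)Nc4cccc(C(F)(F)F)c4)c3)cc2-c2ccncc2)ccc1Cl`, gives 579 nM

Compound 2 has the lowest number of the three. Its gap to compound 3 is small, the step of a 1.4-fold higher number from compound 2 to compound 3 (0.15 log units; within the scatter), so the two cannot be ordered. Its gap to compound 1 is larger: compound 1 gives 1060 nM, a number beyond the scatter above that of compound 2.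

Compound 4, `O=C(Nc1cccc(-n2cc(-c3ccncc3)c(-c3ccc(Cl)c(O)c3)n2)c1)Nc1cc(C(F)(F)F)cc(C(F)(F)F)c1`, comes from compound 2 by one change: hydrogen in place of methyl on an oxygen on an aromatic ring. Going by the values given here, one measured step bears on this directly, in the opposite direction: a 1.8-fold lower number from compound 1 to compound 3 (0.26 log units; within the scatter). That step, methyl in place of hydrogen on the same oxygen, stayed within the scatter. Reversing it on compound 2 should therefore bring no step beyond the scatter in this assay, though the number may lean somewhat higher. Compound 4 is thus expected to give about 700 nM, within a range from 300 nM to 1600 nM, an estimated step of a 1.7-fold higher number from compound 2 to compound 4 (0.23 log units; within the scatter).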

Compound 4, concentration for 50% growth inhibition: 395 nM
Compound 4: middle estimate off by 1.8-fold (0.25 log units), on the high side, and the stated range covers the measured number.
By their numbers in this assay, from the lowest: compounds 4, 2, 3 and 1 (each within the scatter of the next, the first and the last beyond it).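

In this assay, the methoxy to hydroxy change now has a reading on a second core (the step of a 1.0-fold lower number from compound 2 to compound 4 (0.02 log units; within the scatter)), and neither reading of this change on the oxygen goes beyond the scatter, so the free hydroxy and the methoxy cannot be told apart on either core: the same change on two cores in this assay, a 1.8-fold lower number (0.26 log units; within the scatter) from compound 1 to compound 3 and a 1.0-fold higher number (0.02 log units; within the scatter) from compound 4 to compound 2, 1.9-fold (0.28 log units) apart, within the scatter of two such steps. Trifluoromethyl in place of hydrogen on an aromatic carbon now gives its first step beyond the scatter (the step of a 2.7-fold lower number from compound 1 to compound 4 (0.43 log units; beyond the scatter)). The same change stayed within the scatter on the methoxy compounds, yet the two readings do not differ beyond the scatter, so no dependence on the core can be claimed: the same change on two cores in this assay, a 1.4-fold higher number (0.15 log units; within the scatter) from compound 2 to compound 3 and a 2.7-fold higher number (0.43 log units; beyond the scatter) from compound 4 to compound 1, 1.9-fold (0.28 log units) apart, within the scatter of two such steps.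

The compounds shown leave open how a longer chain on that oxygen, such as ethoxy, or an amine in place of the hydroxy would read in this assay. They also leave open whether a nitrile could stand in place of the added trifluoromethyl.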